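Adding a Chlorine to the Terminal Phenyl Ring

A few compounds are considered here, and "the series" means these few. Any claim that something is new, unique, unknown or untested is made for them only; others in the source may bear on it.

Of the compounds shown here, three share a core and have been tested in a functional assay on MGC-803 cells (Homo sapiens) for antiproliferative activity, read by MTT assay; a higher number here means a weaker inhibitor, a lower number a stronger inhibitor. Compound 1, `COc1ccc(NC(=O)Nc2cccc(CNc3ncnc4ccccc34)c2)cc1`, gives 27300 nM. Compound 2, `O=C(Nc1ccc(F)cc1)Nc1cccc(CNc2ncnc3ccccc23)c1`, gives 44300 nM. Compound 3, `COc1cc2ncnc(NCc3cccc(NC(=O)Nc4ccccc4)c3)c2cc1OC`, gives 10000 nM, the lowest of the three numbers, and its gap to each of the others is beyond the usual scatter, so on these figures compound 3 is the strongest inhibitor of the set.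

Compound 4, `COc1cc2ncnc(NCc3cccc(NC(=O)Nc4ccccc4Cl)c3)c2cc1OC`, has not yet been measured. It differs from compound 3 in one place: chloro in place of hydrogen on an aromatic carbon. The new chloro sits on an aromatic carbon of a six-membered aromatic ring of carbon only, ortho to a large group, turning phenyl into 2-chlorophenyl.

Going by the values given here, only one measured step speaks to a swap on that same ring: a 1.6-fold higher number from compound 1 to compound 2 (0.21 log units; within the scatter). That change, a fluoro in place of a methoxy, left the number essentially where it was. With a single comparable step, and that one within the scatter, there is no basis to expect a large move in either direction in this assay.

Compound 4 is therefore expected to land close to compound 3, with a step of a 1.3-fold lower number from compound 3 to compound 4 (0.10 log units; within the scatter), giving an estimate of 8000 nM, in the range 3000 nM to 25000 nM.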

Compound 4, half-maximal inhibitory concentration: 30200 nM
Compound 4: the middle estimate sits 3.8-fold (0.58 log units) below what was measured; the whole stated range lies below it.
By their numbers in this assay, from the lowest: compound 3; then compounds 1, 4 and 2 (each within the scatter of the next).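

In this assay, chloro in place of hydrogen on an aromatic carbon, ortho to a large group, gives a 3.0-fold higher number from compound 3 to compound 4 (0.48 log units; beyond the scatter), so turning phenyl into 2-chlorophenyl makes this compound a weaker inhibitor, and the change is modest but real. Going by these compounds alone, the only earlier step on this ring, a 1.6-fold higher number from compound 1 to compound 2 (0.21 log units; within the scatter), stayed within the scatter and could not show that the ring responds to any change at all; this new step shows that a single added chlorine atom at this place is enough to move the number, and in the unfavourable direction. Nothing available explains the shift, so the reason for it remains unknown.

A single chlorine cannot show whether the drop belongs to chloro itself or would follow any group at this place, and a methyl, a bromo or an amine on the same carbon would help to separate those two readings. On these data alone, it also remains open whether chloro on the other carbons of this ring, or the same 2-chlorophenyl group on the core of compound 1, would shift the number in the same way.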